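Methyl to methoxy swap on the aryl piperazine amide series

The source may hold more compounds than are shown below. What is called first, only, known or untested is meant among the compounds shown, and "the series" means these compounds.

Measured so far in a functional assay on KAN-TS cells for antagonist activity at Neuropeptide Y receptor type 2 (Homo sapiens), read by GTPgammaS binding; on this read-out higher numbers stand for weaker inhibition and lower numbers for stronger inhibition:
compound 1 `CC(C)(C(=O)Nc1ccc(N2CCN(C(=O)c3ccccc3)CC2)c(C(F)(F)F)c1)c1ccccc1`: 631 nM
compound 2 `Cc1cc(NC(=O)C(C)(C)c2ccccc2)ccc1N1CCN(C(=O)c2ccccc2)CC1`: 316 nM

Compound 2 carries the smaller of the two numbers, but the gap to compound 1 is not a real separation: a 2.0-fold lower number from compound 1 to compound 2 (0.30 log units; within the scatter). The two compounds therefore count as equal on this read-out.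

Compound 3 `COc1cc(NC(=O)C(C)(C)c2ccccc2)ccc1N1CCN(C(=O)c2ccccc2)CC1` differs from compound 2 by methoxy in place of methyl on an aromatic carbon. Among the measured compounds shown here, no measured step bears on a methoxy group directly. For the measured compounds named here, the only step in hand, a 2.0-fold lower number from compound 1 to compound 2 (0.30 log units; within the scatter), concerns a different exchange at the same place and stays within the scatter, so the set offers no sign that a small change at this position moves the number. Accordingly no step beyond the scatter is expected in this assay for compound 3, which is estimated at 320 nM with a range of 120 nM to 850 nM. The expected step is a 1.0-fold higher number from compound 2 to compound 3 (0.01 log units; within the scatter).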

Compound 3, inhibition constant: 2510 nM
For compound 3 the middle estimate is 7.8-fold (0.89 log units) below the measured one; measured number outside the range, above it.
By their numbers in this assay, from the lowest: compounds 2 and 1 (each within the scatter of the next); then compound 3.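

In this assay this position proves sensitive to the group it carries: a 7.9-fold higher number from compound 2 to compound 3 (0.90 log units; beyond the scatter), and a 4.0-fold higher number from compound 1 to compound 3 (0.60 log units; beyond the scatter), so the exchange for methoxy moves the number beyond the scatter, whereas methyl and trifluoromethyl did not separate. Compound 3 thus has the weakest inhibition of the three, and of the three groups compared here only methoxy brings an oxygen and a hydrogen-bond acceptor to this aromatic carbon, though that is a difference in structure and not an explanation. Nothing available here accounts for the loss.

Open, going by these compounds, is whether the higher number goes with the oxygen or with the added heavy atom, a question that an ethyl group or a hydroxyl group at this carbon would address. The compounds shown also leave open whether the methoxy step holds when the benzoyl group on the piperazine is replaced.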